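The source may report more compounds than this note shows. Statements on the series, on what has been measured and on what is new or still open speak of the compounds shown alone.

Measured compounds in an ADME assay on Vero cells (Chlorocebus sabaeus) for cytotoxicity, read by MTT assay, with a stated time of 72 h; on this read-out higher numbers stand for weaker inhibition and lower numbers for stronger inhibition:
Compound 1, `CCCNc1nc(=O)c2cc(C(F)(F)F)cc([N+](=O)[O-])c2s1`: in this assay compound 1 gives > 100000 nM, which is a limit of the assay and not a number.
Compound 2, `CC(C)CNc1nc(=O)c2cc(C(F)(F)F)cc([N+](=O)[O-])c2s1`: compound 2 gives > 100000 nM, again a limit of the assay.
Compound 3, `CCN(CC)c1nc(=O)c2cc(C(F)(F)F)cc([N+](=O)[O-])c2s1`: compound 3 gives > 100000 nM, likewise a limit of the assay.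

Compound 3 therefore stands only at a limit, and the two other values shown share that same limit, as summarised by the limit of > 100000 nM in this assay, at which 3 of the 3 values shown sit. The measured steps bring nothing readable: the step from compound 1 to compound 2 is a step that the two limits leave unreadable from compound 1 to compound 2, the step from compound 1 to compound 3 is a step that the two limits leave unreadable from compound 1 to compound 3, and the step from compound 2 to compound 3 is a step that the two limits leave unreadable from compound 2 to compound 3. All three are changes of the amino substituent on the shared core, and none of them moved any value away from the limit.

Compound 4, `O=c1nc(NC2CCCC2)sc2c([N+](=O)[O-])cc(C(F)(F)F)cc12`, differs from compound 3 by cyclopentylamino in place of diethylamino on an aromatic carbon. This is once more a change of the amino substituent on the same aromatic carbon, the kind of change that in this assay left every measured value at the limit. With no readable step available, no step beyond the scatter is expected, and the step from compound 3 to compound 4 is expected to be a step that the limit leaves unreadable from compound 3 to compound 4. Compound 4 is thus estimated at 150000 nM, with an expected range from 80000 nM to 500000 nM, most probably reported only as a limit again.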

Compound 4, half-maximal inhibitory concentration: > 100000 nM
Compound 4: only a limit was reported (the forecaster's own chance of this, stated with the estimate: 85%); the middle value does not contradict the limit.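

In this assay compound 4 gives > 100000 nM as a limit of the assay and not a number. Within the data shown here, its steps from compound 1, compound 2 and compound 3 therefore cannot be read, and no new step follows: the limit of > 100000 nM in this assay, at which 4 of the 4 values shown sit.
The compounds shown leave open how far each of the four lies from that limit, and whether in this assay any amino substituent on the shared core gives a readable value.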